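The source may report more compounds than this note shows. Statements on the series, on what has been measured and on what is new or still open speak of the compounds shown alone.

Measured in a functional assay on K562 cells (Homo sapiens), read by MTT assay, with a stated time of 72 h; a higher number here means a weaker inhibitor, a lower number a stronger inhibitor:
Compound 1 `COc1ncnc2c1c(-c1ccccc1)cn2[C@@H]1O[C@H](CO)[C@@H](O)[C@H]1O`: > 20000 nM, a limit
Compound 2 `C#Cc1cn([C@@H]2O[C@H](CO)[C@@H](O)[C@H]2O)c2ncnc(OC)c12`: 380 nM
Compound 3 `CSc1ncnc2c1c(-c1cccs1)cn2[C@@H]1O[C@H](CO)[C@@H](O)[C@H]1O`: > 20000 nM, a limit

Compound 3 stands at the limit of > 20000 nM in this assay, at which 2 of the 3 values shown sit, so its entry is a limit and not a number. Compound 4 `CSc1ncnc2c1c(-c1ccccc1)cn2[C@@H]1O[C@H](CO)[C@@H](O)[C@H]1O` has phenyl in place of thiophen-2-yl on an aromatic carbon. Going by the values given here, the one measured step, an at least 52-fold lower number from compound 1 to compound 2 (1.72 log units; beyond the scatter), is large, but it puts ethynyl in place of phenyl, so it bears only indirectly. Among the compounds with values here, no measured step exchanges one aromatic ring for another. Compound 1, which also carries phenyl, gives > 20000 nM, again a limit. No step beyond the scatter is therefore expected in this assay. The expected step is a number no higher from compound 3 to compound 4 (the limit leaves the size open). For compound 4 the estimated value is 20000 nM, with an expected range of 6000 nM to 40000 nM.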

Compound 4, half-maximal inhibitory concentration: > 20000 nM
Compound 4 ended at the assay's limit; the forecaster's own chance of this, stated with the estimate: 75%; the middle value lies on the limit itself.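

In this assay compound 4 gives a limit (> 20000 nM). Going by these compounds alone, compound 1, compound 3 and compound 4 all sit at this limit, so no step among them can be read. On these data alone, whether phenyl or thiophen-2-yl, or methoxy or methylsulfanyl, gives the lower number in this assay stays open.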